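The source may report more compounds than this note shows. Statements on the series, on what has been measured and on what is new or still open speak of the compounds shown alone.

In a functional assay on Jurkat cells (Homo sapiens) for antiproliferative activity, read by MTT assay, with a stated time of 72 h (on this read-out lower numbers stand for stronger inhibition and higher numbers for weaker inhibition), compound 1 `COc1cc(-c2ncnn2-c2ccc(Cl)cc2Cl)cc(OC)c1OC` reads > 10000 nM, which is a limit. Compound 2 `COc1cc(-c2ncnn2-c2ccc([N+](=O)[O-])cc2)cc(OC)c1OC` reads > 10000 nM, again a limit, so it stands at the limit of > 10000 nM in this assay, at which 2 of the 2 values shown sit, and no order can be read between the two compounds. Compound 3 `COc1ccc(-n2ncnc2-c2cc(OC)c(OC)c(OC)c2)cc1` is compound 2 with one change, methoxy in place of nitro on an aromatic carbon, para to a large group. Among the compounds with values here, no measured step is available as a guide, so the expectation is loose: an estimated step of an at least 5.0-fold lower number from compound 2 to compound 3 (0.69 log units; beyond the scatter) toward stronger inhibition, of uncertain size. For compound 3 the estimate is 2000 nM, with an expected range of 150 nM to 15000 nM.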

Compound 3, half-maximal inhibitory concentration: 93 nM
For compound 3 the middle estimate is 22-fold (1.33 log units) above the measured one, outside the stated range (below it).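

Methoxy in place of nitro on an aromatic carbon, para to a large group, gives an at least 100-fold lower number from compound 2 to compound 3 (2.03 log units; beyond the scatter) in this assay and turns this position from a limit into a measured value. The step of an at least 100-fold lower number from compound 1 to compound 3 (2.03 log units; beyond the scatter) with 4-methoxyphenyl in place of 2,4-dichlorophenyl on an aromatic nitrogen reaches the same result from a second starting point, so the substitution on this ring carries large weight in the series. Both steps are bounds and not exact sizes, as their starting values are limits: the limit of > 10000 nM in this assay, at which 2 of the 3 values shown sit.

Open, going by these compounds, is how narrowly this position tolerates change: whether an ethoxy, a hydroxyl or an amine there would hold the activity of compound 3 remains unknown.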